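The compounds below may be only part of what the source reports. "The series", "measured", "known", "first", "only" and "open" are said of these compounds alone.

Working notes on the series. Within the data shown here, in a functional assay on MDA-MB-231 cells (Homo sapiens) for antiproliferative activity, read by sulforhodamine B assay, with a stated time of 72 h (on this read-out lower numbers stand for stronger inhibition and higher numbers for weaker inhibition), compound 1 (`O=C(/C=C/c1csc2ccccc12)c1cc(Br)ccc1O`) gives 840 nM, the lowest number of the three measured so far. Compound 2 (`O=C(/C=C/c1csc2ccccc12)c1cc(Cl)cc(Cl)c1O`) gives 3300 nM, and compound 3 (`O=C(/C=C/c1csc2ccccc12)c1cc(Br)cc(Br)c1O`) gives 4300 nM. The gaps from compound 1 to both of these lie beyond the scatter.

The next case is compound 4 (`CCOc1ccc(O)c(C(=O)/C=C/c2csc3ccccc23)c1`), which has ethoxy in place of bromo on an aromatic carbon, para to a hydroxy group (ethoxy in place of bromo on an aromatic carbon).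

Among the measured compounds shown here, only one measured step involves a single change: a 5.1-fold higher number from compound 1 to compound 3 (0.71 log units; beyond the scatter), a modest step with bromo in place of hydrogen on an aromatic carbon. It bears on the new change only indirectly, as it keeps the bromo of compound 1 and adds a second one. For the measured compounds named here, no measured compound carries ethoxy, and no measured step removes this bromo. The data therefore give neither the size nor the direction of the step directly.

Going by the values given here, compound 1 holds the lowest number so far, so a small rise in this assay is the more likely outcome, though one smaller than the step to compound 3. The expected step is a 1.8-fold higher number from compound 1 to compound 4 (0.25 log units; within the scatter), which would not clearly exceed the scatter. For compound 4 the estimated value is 1500 nM. The estimated range for compound 4 runs from 500 nM to 4500 nM.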

Compound 4, half-maximal inhibitory concentration: 6700 nM
For compound 4 the middle estimate is 4.5-fold (0.65 log units) below the measured one, and the stated range ends below it.
By their numbers in this assay, from the lowest: compound 1; then compounds 2, 3 and 4 (each within the scatter of the next, the first and the last beyond it).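

The replacement at this position is now measured directly: ethoxy in place of bromo, on the aromatic carbon para to a hydroxy group, gives an 8.0-fold higher number from compound 1 to compound 4 (0.90 log units; beyond the scatter) in this assay. Among these compounds, until now the only single change was the addition seen in a 5.1-fold higher number from compound 1 to compound 3 (0.71 log units; beyond the scatter), which keeps this bromo, so compound 4 is the first case where the bromo itself is replaced, and that replacement also raises the number beyond the scatter. Nothing measured here accounts for the rise from compound 1 to compound 4.

The compounds shown do not separate the loss of bromo from the arrival of ethoxy, and a compound with hydrogen at this position on the otherwise unchanged core of compound 1 would be needed to tell the two apart. Going by these compounds, it also remains open whether the rise is particular to ethoxy or extends to other groups at this position, such as methoxy, chloro, an amine or a longer alkoxy chain.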